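The compounds below may be only part of what the source reports. "The series", "measured", "known", "first", "only" and "open" are said of these compounds alone.

In an ADME assay on MRC5 cells (Homo sapiens), read by MTT assay, with a stated time of 72 h (a lower number here means a stronger inhibitor, a higher number a weaker inhibitor), all the measurements so far sit at the same limit, as the limit of > 100000 nM in this assay, at which 3 of the 3 values shown sit, shows. Compound 3 `CNc1ncnc2c1c(-c1ccsc1)cn2[C@@H]1O[C@H](CO)[C@@H](O)[C@H]1O` reads > 100000 nM, which is a limit and not a number. Compound 2 `CNc1ncnc2c1c(-c1cccs1)cn2[C@@H]1O[C@H](CO)[C@@H](O)[C@H]1O` reads > 100000 nM, also a limit.

Compound 4 `C#Cc1cn([C@@H]2O[C@H](CO)[C@@H](O)[C@H]2O)c2ncnc(NC)c12` comes from compound 3 through a single change: ethynyl in place of thiophen-3-yl on an aromatic carbon. Going by the values given here, the only measured step between two such close relatives is a step that the two limits leave unreadable from compound 2 to compound 3, where thiophen-3-yl takes the place of thiophen-2-yl. Its size cannot be read, so it offers no measure for the new change. The ethynyl group does already appear in the set: compound 1 `C#Cc1cn([C@@H]2O[C@H](CO)[C@@H](O)[C@H]2O)c2ncnc(OC)c12` carries it and reads > 100000 nM, again a limit. On that basis, no step beyond the usual scatter is expected, and the result will most likely stay at the limit. The expected size is a number no higher from compound 3 to compound 4 (the limit leaves the size open). Compound 4 is estimated at 100000 nM, with an expected range from 30000 nM to 150000 nM.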

Compound 4, half-maximal inhibitory concentration: > 100000 nM
Compound 4: only a limit was reported; the forecaster's own chance of this, stated with the estimate: 65%; the middle value lies on the limit itself.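

Compound 4 gives a limit and not a number, as do compounds 1, 2 and 3, so no step from any of them to compound 4 can be read; all four rest on the same value: the limit of > 100000 nM in this assay, at which 4 of the 4 values shown sit.

The compounds shown leave open which change on the shared core, if any, would give a measurable number in this assay.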